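The source may report more compounds than this note shows. Statements on the series, on what has been measured and on what is new or still open speak of the compounds shown alone.

Measured compounds so far:

- Compound 1 `O=C(NC(=S)N1CCc2c(OCCCCCOc3ccc(Cl)cc3)cccc21)c1ccc(Br)cc1`; in an ADME assay on Huh-7 cells (Homo sapiens) for cytotoxicity (on this read-out lower numbers stand for higher toxicity in this test and higher numbers for lower toxicity in this test), compound 1 gives 29100 nM.
- Compound 2 `CN(C)c1ccc(C(=O)NC(=S)N2CCc3c(OCCCCCOc4ccc(Cl)cc4)cccc32)cc1`; in this assay compound 2 gives > 50000 nM, a limit of the assay and not a number.
- Compound 3 `O=C(NC(=S)N1CCc2c(OCCCCCOc3ccc(Cl)cc3)cccc21)C1CCCC1`; in this assay compound 3 gives > 50000 nM, again a limit of the assay and not a number.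

Compound 3 therefore stands at the upper limit of this assay, and the same holds for compound 2, as noted in the limit of > 50000 nM in this assay, at which 2 of the 3 values shown sit. Only compound 1 returns a number, and the step of an at least 1.7-fold higher number from compound 1 to compound 3 (0.23 log units; that floor lies within the scatter) has a floor that still lies within the scatter, so compound 3 is not separable from compound 1 on these values. The step that the two limits leave unreadable from compound 2 to compound 3 is not readable at all.

Compound 4 `O=C(NC(=S)N1CCc2c(OCCCCCOc3ccc(Cl)cc3)cccc21)c1ccno1` carries the change (1,2-oxazol-5-yl in place of cyclopentyl on a carbonyl carbon). For the measured compounds named here, the only step that bears on it is the amide-side exchange an at least 1.7-fold higher number from compound 1 to compound 3 (0.23 log units; that floor lies within the scatter), which went from an aryl amide to the cyclopentyl amide and remained within scatter. Returning to an aromatic ring at this position is therefore expected to give a step of about an at least 1.2-fold lower number from compound 3 to compound 4 (0.09 log units; that floor lies within the scatter) in this assay, with no clear direction beyond the scatter. Compound 4 is estimated at 40000 nM in this assay, within 20000 nM to 80000 nM.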

Compound 4, half-maximal cytotoxic concentration: 37100 nM
Compound 4: the middle estimate sits 1.1-fold (0.03 log units) above what was measured; the range from low to high includes it.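

In this assay the exchange of 4-bromophenyl for 1,2-oxazol-5-yl on the carbonyl carbon gives a 1.3-fold higher number from compound 1 to compound 4 (0.11 log units; within the scatter), so this position now holds two read numbers that cannot be told apart. The floors of the other two steps are an at least 1.3-fold lower number from compound 3 to compound 4 (0.12 log units; that floor lies within the scatter) and an at least 1.3-fold lower number from compound 2 to compound 4 (0.12 log units; that floor lies within the scatter), so neither the cyclopentyl nor the 4-(dimethylamino)phenyl exchange separates from the 1,2-oxazol-5-yl group on these values. The values of compound 2 and compound 3 are limits and not numbers, which leaves the true size of both steps unknown: the limit of > 50000 nM in this assay, at which 2 of the 4 values shown sit.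

On these data alone, whether a piperidine ring with its basic amine or a benzoic acid group on this carbonyl carbon would move the number beyond the scatter stays open. Also open, as far as these compounds go, is whether a longer chain in the shared core would do so.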